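From Difluorophenyl to Dichlorophenyl on a Ring Nitrogen

A few compounds are considered here, and "the series" means these few. Any claim that something is new, unique, unknown or untested is made for them only; others in the source may bear on it.

Compound 1 `Nc1scc(CN2CCN(c3ccncc3)CC2)c1C(=O)c1ccc(Cl)cc1`: 2%
Compound 2 `Nc1scc(CN2CCN(c3ccc(F)c(F)c3)CC2)c1C(=O)c1ccc(Cl)cc1`: 1%

Of the compounds shown here, two sharing one core have been tested in an assay on CHO cells for displacement of a labelled ligand from adenosine receptor A3 (Homo sapiens), read by scintillation counting, with a stated time of 120 min, tested at 10 uM; a higher number here means more inhibition at the concentration tested (going by the name of the read-out), a lower number less inhibition. In this assay compound 1 gives 2%, and compound 2 gives 1%. Both numbers sit close to zero, meaning that at the tested concentration neither compound displaces much of the labelled ligand. Compound 2 holds the lowest of the two numbers, with compound 1 nearest; the step of a number 1 percentage points lower from compound 1 to compound 2 (within the scatter) is within the scatter, so the two compounds cannot be told apart on these data.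

Compound 3 `Nc1scc(CN2CCN(c3ccc(Cl)c(Cl)c3)CC2)c1C(=O)c1ccc(Cl)cc1` carries a change at the same place as that step: 3,4-dichlorophenyl in place of 3,4-difluorophenyl on an amine nitrogen in a ring. Going by the values given here, only one measured step bears on it, a number 1 percentage points lower from compound 1 to compound 2 (within the scatter), and it exchanged a different pair of groups, yet it showed that altering this aryl group left the number within the scatter. With both measured values near zero, no movement beyond the scatter is expected; the step of a number 2 percentage points higher from compound 2 to compound 3 (within the scatter) is the estimated outcome. Compound 3 is therefore expected to give 3%, with a range from -8% to 16%.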

Compound 3, a percentage reported as inhibition, at one concentration (the size of the read-out at that concentration, not a potency): 3%
Beside the measured number, compound 3's estimate shows no gap at the digits printed; low and high end bracket the measured number.
By their numbers in this assay, from the lowest: compounds 2, 1 and 3 (each within the scatter of the next).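

In this assay the exchange of 3,4-difluorophenyl for 3,4-dichlorophenyl gives a number 2 percentage points higher from compound 2 to compound 3 (within the scatter) at this amine nitrogen in a ring, and 3,4-dichlorophenyl in place of pyridin-4-yl gives a number 1 percentage points higher from compound 1 to compound 3 (within the scatter) at the same place. The position has now carried a ring with nitrogen and carbon-only rings with two different halogens, and the read-out separates none of the three, with every number still close to zero at the tested concentration. Nothing available explains why these numbers stay so close together.

As far as these compounds go, it remains open whether anything on this nitrogen can lift the number beyond the scatter, for example a cyclohexyl ring, a benzyl group or a plain alkyl chain in place of the aromatic rings directly attached here. Also open, from the compounds shown here alone, is whether a change elsewhere on the shared core, such as a carboxylic acid or an amide in place of the amine on the core, would move the result when the group on this nitrogen stays the same.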